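This account rests on a few compounds, and the source may have more. Where it says the series, first, only, none or still open, it means among the compounds named here.

Of the compounds shown here, three have so far been tested in a functional assay on K562 cells (Homo sapiens) for antiproliferative activity, read by MTT assay, with a stated time of 48 h; a lower number here means a stronger inhibitor, a higher number a weaker inhibitor. Compound 1 `CCOC(=O)N1CCC(N(Cc2cccc([N+](=O)[O-])c2)C(=O)N(C)C)CC1` gives 26000 nM. Compound 3 `CCOC(=O)N1CCC(N(Cc2ccc([N+](=O)[O-])cc2)C(=O)N(C)C)CC1` gives 26000 nM; it carries a 4-nitrophenyl where compound 1 carries a 3-nitrophenyl, and the step of no change at the digits printed from compound 1 to compound 3 (within the scatter). Compound 2 `CN(C)C(=O)N(Cc1ccc([N+](=O)[O-])cc1)Cc1ccco1`, built on a different core, gives 35400 nM. Compound 1 therefore stands level with compound 3 at the digits shown, and compound 2 lies within the scatter of both, so none of the three separates from the others in this assay.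

Compound 4 `CCOC(=O)N1CCC(N(Cc2cc([N+](=O)[O-])ccc2O)C(=O)N(C)C)CC1` has not yet been measured. It differs from compound 1 in a single place: hydroxy in place of hydrogen on an aromatic carbon. For the measured compounds named here, no measured step adds a hydroxy, or any other group, to this ring; the only step within the set, no change at the digits printed from compound 1 to compound 3 (within the scatter), moved the nitro group around the ring and left the number unchanged. The data thus give no sign of a shift in either direction, and the estimated step is no change at the digits printed from compound 1 to compound 4 (within the scatter) in this assay, which amounts to no change beyond the scatter. Compound 4 is accordingly expected to give about 26000 nM, within a range from 10000 nM to 65000 nM.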

Compound 4, half-maximal inhibitory concentration: 38400 nM
Compound 4: middle estimate off by 1.5-fold (0.17 log units), on the low side; the measured number falls inside the stated range.
By their numbers in this assay, from the lowest: compounds 1, 3, 2 and 4 (each within the scatter of the next).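

Hydroxy is the first group in this set to be added to the nitrophenyl ring rather than moved around it, and it sits on an aromatic carbon ortho to a large group and para to a nitro group. In this assay, this replacement of hydrogen gives a 1.5-fold higher number from compound 1 to compound 4 (0.17 log units; within the scatter), so this carbon can carry a group with one hydrogen-bond donor and one hydrogen-bond acceptor without the number leaving the scatter, something the earlier shift of the nitro group could not show. No measurement available here bears on what lies behind this small step.

The compounds shown leave open whether a methoxy, an amine or a carboxylic acid on this same carbon would also stay within the scatter of compound 1, or whether any group here could move the number beyond it. They also leave open whether adding hydroxy would give a similar result on the 4-nitrophenyl ring of compound 3 or on the different core of compound 2.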